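Removing the Benzyl Group from a Nucleoside Analogue

The source may hold more compounds than are shown below. What is called first, only, known or untested is meant among the compounds shown, and "the series" means these compounds.

Measured so far:
Compound 1, `OC[C@@]1(O)CO[C@@H](n2cnc3c(NCc4cccc(Cl)c4)ncnc32)[C@@H]1O`: 43%
Compound 2, `OC[C@]1(O)CO[C@@H](n2cnc3c(NCc4cccc(I)c4)ncnc32)[C@@H]1O`: 45%

In an assay on CHO cells for displacement of a labelled ligand from adenosine receptor A3 (Homo sapiens), tested at 10 uM (on this read-out higher numbers stand for more inhibition at the one concentration tested (going by the name of the read-out) and lower numbers for less inhibition), compound 2 gives 45%, the higher of the two numbers recorded. Its nearest neighbour, compound 1, gives 43%, and the gap between the two lies within the scatter of repeated measurements, so neither number can be called the higher one. Compound 3, `Nc1ncnc2c1ncn2[C@@H]1OC[C@@](O)(CO)[C@H]1O`, has not yet been tested in this assay. It differs from compound 2 in one place: hydrogen in place of 3-iodobenzyl on a nitrogen on an aromatic ring. Within the data shown here, no step between measured compounds is available for this kind of change, so the expectation for compound 3 rests only on the two values at hand and on the size of the group that is lost. Compound 3 is expected to show a drop beyond the scatter, with an estimated step of a number 27 percentage points lower from compound 2 to compound 3 (beyond the scatter). The estimated value for compound 3 is 18%, within a range from 3% to 38%.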

Compound 3, a percentage reported as inhibition, at one concentration (the size of the read-out at that concentration, not a potency): 10%
Beside the measured number, compound 3's estimate is 8 percentage points above it; measured number inside the range.
By their numbers in this assay, from the lowest: compound 3; then compounds 1 and 2 (each within the scatter of the next).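

In this assay the swap of 3-iodobenzyl for hydrogen on the nitrogen gives a number 35 percentage points lower from compound 2 to compound 3 (beyond the scatter) and turns (3-iodobenzyl)amino into a bare amino group. Among these compounds, this is the first step at this position, and it shows that the inhibition seen for compound 2 does not come from the rest of the molecule alone: without the 3-iodobenzyl group, compound 3 retains only 10% at the one concentration tested. Nothing measured here accounts for the size of this loss.

From the compounds shown here alone, what a plain benzyl, a methyl or a longer phenylethyl chain on that nitrogen would give remains open. So does the question of how much of the step belongs to the iodine and how much to the benzyl group that carries it.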